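Quinoxaline sulfone anilines: a methoxy addition on the aniline ring

The source may hold more compounds than are shown below. What is called first, only, known or untested is meant among the compounds shown, and "the series" means these compounds.

Measured so far:
compound 1 `COc1cc(Nc2nc3ccccc3nc2S(=O)(=O)c2ccccc2)cc(OC)c1OC` — 9660 nM
compound 2 `COc1ccc(S(=O)(=O)c2nc3ccccc3nc2Nc2cc(OC)c(OC)c(OC)c2)cc1` — 5170 nM
compound 3 `COc1cc(Nc2nc3ccccc3nc2S(=O)(=O)c2ccc(F)cc2)cc(OC)c1` — 5450 nM

In a functional assay on A549 cells (Homo sapiens) for cytotoxicity, read by MTT assay, with a stated time of 72 h (on this read-out lower numbers stand for stronger inhibition and higher numbers for weaker inhibition), compound 3 stands second highest of the three numbers, within the scatter of both neighbours: compound 2 sits close to it, and compound 1, which gives 9660 nM, lies furthest away but still within the scatter. Compound 4 `COc1cc(Nc2nc3ccccc3nc2S(=O)(=O)c2ccc(F)cc2)cc(OC)c1OC` differs from compound 3 by methoxy in place of hydrogen on an aromatic carbon.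

Within the data shown here, only one measured step in this assay involves a methoxy entering in place of hydrogen: a 1.9-fold lower number from compound 1 to compound 2 (0.27 log units; within the scatter). Among the measured compounds shown here, that step sits on the other aromatic ring, the one carrying the sulfonyl group, so it bears on the present change only loosely; no measured pair isolates a methoxy addition on the aniline ring itself. Compounds 1 and 3 differ in two places and their values lie within the scatter of each other.

Given that all three measured numbers lie within the scatter of each other, compound 4 is expected to stay in the same range, with no step beyond the scatter, a 1.1-fold higher number from compound 3 to compound 4 (0.04 log units; within the scatter). The estimate for compound 4 in this assay is 6000 nM, with a range from 2500 nM to 15000 nM.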

Compound 4, half-maximal inhibitory concentration: > 50000 nM
Compound 4 was reported as a limit; the forecaster's own chance of this, stated with the estimate: 5%; middle value at least 8.3-fold (0.92 log units) away from the limit.
By their numbers in this assay, from the lowest: compounds 2, 3 and 1 (each within the scatter of the next). At a limit, above all of these: compound 4.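

In this assay compound 4 stands only as a limit, > 50000 nM. The methoxy entering ortho to two methoxy groups and para to a large group is far from neutral when fluoro sits on the ring carrying the sulfonyl group, with an at least 9.1-fold higher number from compound 3 to compound 4 (0.96 log units; beyond the scatter), and the fluoro itself matters once this methoxy is present, with an at least 5.1-fold higher number from compound 1 to compound 4 (0.71 log units; beyond the scatter) and an at least 9.6-fold higher number from compound 2 to compound 4 (0.98 log units; beyond the scatter). The earlier compounds gave no sign that the effect of a methoxy addition depends on its setting, and the two changes do not behave alike: the same change on two cores in this assay, a 1.9-fold lower number (0.27 log units; within the scatter) from compound 1 to compound 2 and an at least 9.1-fold higher number (0.96 log units; beyond the scatter) from compound 3 to compound 4, at least 17-fold (1.23 log units) apart, beyond the scatter of two such steps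

The limit leaves the true size of all three steps unknown. On these data alone, whether a hydroxy or an amine at this position, or a chloro in place of the fluoro, would give a value inside the range of the assay stays open.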